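Phenyl for furan-3-yl on the fused five-membered ring

A few compounds are considered here, and "the series" means these few. Any claim that something is new, unique, unknown or untested is made for them only; others in the source may bear on it.

Compound 1 `Nc1nc2c(c(-c3ccccc3)cn2[C@@H]2O[C@H](CO)[C@@H](O)[C@H]2O)c(=O)[nH]1` in a functional assay on HeLa S3 cells (Homo sapiens) for antiproliferative activity, read by XTT assay, with a stated time of 72 h; on this read-out higher numbers stand for weaker inhibition and lower numbers for stronger inhibition: compound 1 gives > 20000 nM, a limit of the assay.
Compound 2 `O=c1[nH]cnc2c1c(-c1ccco1)cn2[C@@H]1O[C@H](CO)[C@@H](O)[C@H]1O`: compound 2 gives 5780 nM.
Compound 3 `O=c1[nH]cnc2c1c(-c1ccoc1)cn2[C@@H]1O[C@H](CO)[C@@H](O)[C@H]1O`: compound 3 gives > 20000 nM, a limit of the assay.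

Compound 3 stands at the limit of > 20000 nM in this assay, at which 2 of the 3 values shown sit; its number is not known, only that it lies at this limit. Among the compounds with values here, the only measured step, an at least 3.4-fold higher number from compound 2 to compound 3 (0.53 log units; beyond the scatter), concerns the two furans and does not itself reach the phenyl. Compound 4 `O=c1[nH]cnc2c1c(-c1ccccc1)cn2[C@@H]1O[C@H](CO)[C@@H](O)[C@H]1O` carries the change (phenyl in place of furan-3-yl on an aromatic carbon). Within the data shown here, compound 1 bears the same phenyl on a core that differs in one group and also sits at a limit; that pair has no measured step, so the two limits alone are the guide. Compound 4 is therefore expected to remain at or near the limit, with a step that the limit leaves unreadable from compound 3 to compound 4 expected to be no real step beyond the scatter. The estimate for compound 4 in this assay is 25000 nM, within 8000 nM to 80000 nM.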

Compound 4, half-maximal inhibitory concentration: > 20000 nM
Compound 4: no number, only a limit; the forecaster's own chance of this, stated with the estimate: 70%; the middle value lies beyond the limit too.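

In this assay, phenyl in place of furan-2-yl gives an at least 3.4-fold higher number from compound 2 to compound 4 (0.53 log units; beyond the scatter), so at this aromatic carbon the phenyl falls on the same side of compound 2 as furan-3-yl. Compound 4 gives > 20000 nM, a limit of the assay. The steps to compound 4 from compound 3 and from compound 1 cannot be read, and compound 2 alone keeps a number: the limit of > 20000 nM in this assay, at which 3 of the 4 values shown sit.

From the compounds shown here alone, whether a thiophene ring or an amine on this carbon would give a number stays open. So does whether furan-2-yl keeps its number on the core of compound 1.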